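The source may report more compounds than this note shows. Statements on the series, on what has been measured and on what is new or still open speak of the compounds shown alone.

Compounds so far: compound 1 `Cc1nc2c(OCc3ccccc3)cccn2c1C(N)=O` 2%; compound 2 `CSCc1c(C)nc2c(OCc3ccccc3)cccn12` 8%.

In a functional assay on the whole organism (stomach) for inhibition, with Canis familiaris (Canis lupus familiaris) as the target, at a dose of 5 mg/kg by the intravenous route (on this read-out lower numbers stand for a weaker effect and higher numbers for a stronger effect at the one dose given), compound 2 holds the higher of the two numbers, though its step of a number 6 percentage points higher from compound 1 to compound 2 (within the scatter) lies within the scatter, so compound 1 and compound 2 cannot be told apart. Compound 3 `Cc1nc2c(OCc3ccccc3)cccn2c1C[S+](C)[O-]` carries a group of 3 heavy atoms (1 carbon, 1 oxygen, 1 sulfur; no ring) in place of a group of 2 heavy atoms (1 carbon, 1 sulfur; no ring), on a saturated chain carbon bound to an aromatic carbon. Within the data shown here, no measured step touches this kind of change; the only step known concerns a different position. Both measured numbers sit near the bottom of the read-out, so compound 3 is expected to stay there as well, with a step of no change at the digits printed from compound 2 to compound 3 (within the scatter) not beyond the scatter. The estimate for compound 3 is 8%, ranging from 0% to 22%.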

Compound 3, a percentage reported as inhibition, in the whole organism at one dose (the size of the read-out at that dose, not a potency): 18%
Compound 3: middle estimate off by 10 percentage points, on the low side; low and high end bracket the measured number.
By their numbers in this assay, from the lowest: compounds 1, 2 and 3 (each within the scatter of the next, the first and the last beyond it).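

In this assay, the group of 3 heavy atoms (1 carbon, 1 oxygen, 1 sulfur) in place of methylsulfanyl, on a saturated chain carbon bound to an aromatic carbon, gives a number 10 percentage points higher from compound 2 to compound 3 (within the scatter), so this change cannot be told apart from no effect. Among these compounds, the replacement of carbamoyl on an aromatic carbon gives a number 16 percentage points higher from compound 1 to compound 3 (beyond the scatter), the first step to clear the scatter, though only modestly. From the compounds shown here alone, whether an amine, a carboxylic acid or a longer chain in place of methylsulfanyl would clear the scatter stays open. No evidence on the cause of either step is available.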